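Thiourea Cytotoxicity: Replacing an Aryl Arm with an Alkyl Chain

The compounds below may be only part of what the source reports. "The series", "measured", "known", "first", "only" and "open" are said of these compounds alone.

Measured compounds:
compound 1 `FC(F)(F)c1cccc(NC(=S)Nc2ccc(I)cc2)c1` gives 10000 nM in an ADME assay on MT4 cells (Homo sapiens) for cytotoxicity; on this read-out lower numbers stand for higher toxicity in this test and higher numbers for lower toxicity in this test
compound 2 `O=[N+]([O-])c1ccc(NC(=S)Nc2cccc(C(F)(F)F)c2)cc1` gives 9200 nM in this assay
compound 3 `N#Cc1ccc(NC(=S)Nc2cccc(C(F)(F)F)c2)cc1` gives 7000 nM in this assay

Three thioureas sharing the same core have been measured in this assay. Compound 1 stands at the highest of the three numbers, but its nearest neighbour is compound 2 at a 1.1-fold lower number from compound 1 to compound 2 (0.04 log units; within the scatter) and its furthest is compound 3 at a 1.4-fold lower number from compound 1 to compound 3 (0.15 log units; within the scatter), so all three sit within the scatter of one another; the remaining pair, a 1.3-fold lower number from compound 2 to compound 3 (0.12 log units; within the scatter), is equally small. Every one of these steps swaps the substituent on the aromatic ring attached to the amide-type nitrogen, and none of them moved the read-out beyond the scatter.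

Compound 4 `CSCCCNC(=S)Nc1cccc(C(F)(F)F)c1` is not yet measured. Relative to compound 1 it carries 3-(methylsulfanyl)propyl in place of 4-iodophenyl on an amide-type nitrogen. Within the data shown here, no measured step touches a change of this kind: the three known steps only exchange one group on the ring for another, whereas here the whole ring leaves and a chain enters. Among the measured compounds shown here, with no precedent in the data, the account expects a step of a 1.2-fold higher number from compound 1 to compound 4 (0.08 log units; within the scatter), that is, no change beyond the scatter. Compound 4 is therefore estimated at 12000 nM, with a range from 4000 nM to 40000 nM.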

Compound 4, half-maximal cytotoxic concentration: 43000 nM
The estimate for compound 4 lay 3.6-fold (0.55 log units) below the measured number; the whole stated range lies below it.
By their numbers in this assay, from the lowest: compounds 3, 2 and 1 (each within the scatter of the next); then compound 4.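

Among these compounds, replacing the whole 4-iodophenyl with 3-(methylsulfanyl)propyl on the amide-type nitrogen is the first change in this assay to move the read-out beyond the scatter, giving a 4.3-fold higher number from compound 1 to compound 4 (0.63 log units; beyond the scatter) in a step of modest size, whereas the exchanges of one ring substituent among compounds 1, 2 and 3 did not. This position, which showed no response to those swaps on the ring, does respond when the ring itself leaves and a chain with no ring enters, and the shift is towards lower toxicity in this test. Nothing available here bears on why the number rose, so the result stands without an explanation.

Going by these compounds, with only one chain in the set, it remains open whether the rise belongs to the loss of the aromatic ring or to the sulfur in the chain, which a plain butyl chain, a 3-methoxypropyl chain or a benzyl group on this nitrogen would help to separate. On these data alone, it is also open whether a longer chain, or a chain ending in an amine or a carboxylic acid, would keep the number at this level.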